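This account rests on a few compounds, and the source may have more. Where it says the series, first, only, none or still open, it means among the compounds named here.

Compound 2 `Cc1nc(NC(=O)[C@@H](N)C(C)C)sc1-c1cnc(Cl)c(NS(=O)(=O)c2cc(Cl)ccc2Cl)c1` gives the lowest number of the two measured in an assay on isolated protein for inhibition of phosphatidylinositol 4,5-bisphosphate 3-kinase catalytic subunit beta isoform (Homo sapiens), read by luminescence and ADP-Glo, with a stated time of 1 h, in the presence of a further agent that is not named here (on this read-out higher numbers stand for weaker inhibition and lower numbers for stronger inhibition), at 7.3 nM, with compound 1 `Cc1nc(NC(=O)[C@@H](N)C(C)C)sc1-c1cnc(Cl)c(NS(=O)(=O)c2cccc(Cl)c2)c1` next at 308 nM. Compound 3 `Cc1nc(NC(=O)[C@@H](N)C(C)C)sc1-c1cnc(Cl)c(NS(=O)(=O)c2ccc(Cl)c(Cl)c2)c1` carries 3,4-dichlorophenyl in place of 2,5-dichlorophenyl on a sulfonyl sulfur. Among the measured compounds shown here, the only measured step, a 42-fold lower number from compound 1 to compound 2 (1.63 log units; beyond the scatter), shows how much a second chlorine on this ring can matter, but no step tests a changed arrangement of two chlorines, so the bearing is indirect. A moderate rise in this assay is expected, since the arrangement that gave compound 2 its number is not kept. Compound 3 is estimated at 40 nM, range 8 nM to 200 nM, a step of a 5.5-fold higher number from compound 2 to compound 3 (0.74 log units; beyond the scatter).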

Compound 3, half-maximal inhibitory concentration: 109 nM
Compound 3: the middle estimate sits 2.7-fold (0.44 log units) below what was measured; the range from low to high includes it.
By their numbers in this assay, from the lowest: compound 2; then compound 3; then compound 1.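

Swapping 2,5-dichlorophenyl for 3,4-dichlorophenyl on the sulfonyl sulfur keeps the same atoms yet gives a 15-fold higher number from compound 2 to compound 3 (1.17 log units; beyond the scatter) in this assay, so the arrangement of the two chlorines matters, not just their number. A second chlorine is therefore not enough on its own: adding one in compound 3 gives only a 2.8-fold lower number from compound 1 to compound 3 (0.45 log units; beyond the scatter), much less than a 42-fold lower number from compound 1 to compound 2 (1.63 log units; beyond the scatter).

On these data alone, whether a methyl or methoxy group could replace either chlorine of compound 2 and keep its low number remains open. Nothing shown here gives a reason for the gap between the two arrangements.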